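Methylsulfanyl replaced by a selenium-bearing group: series notes

The source may report more compounds than this note shows. Statements on the series, on what has been measured and on what is new or still open speak of the compounds shown alone.

Compound 1 `CS/C(=N\C(=O)c1csc([N+](=O)[O-])c1)NC(=O)c1csc([N+](=O)[O-])c1`: in a functional assay on PC-3 cells (Homo sapiens) for cytotoxicity, read by MTT assay, with a stated time of 72 h (a lower number here means that less compound is tolerated, a higher number that more compound is tolerated), compound 1 gives a limit, > 100000 nM.
Compound 2 `CS/C(=N\C(=O)c1cc2ccccc2s1)NC(=O)c1cc2ccccc2s1`: in this assay compound 2 gives 72600 nM.
Compound 3 `O=C(/N=C(/NC(=O)c1csc([N+](=O)[O-])c1)[Se]Cc1ccccc1)c1csc([N+](=O)[O-])c1`: in this assay compound 3 gives a limit, > 100000 nM.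

Going by the values given here, compound 2 gives the only number; the other two values are limits. The change a group of 8 heavy atoms (7 carbon, 1 selenium; one six-membered aromatic ring of carbon only) in place of a group of 2 heavy atoms (1 carbon, 1 sulfur; no ring), on a carbon with a double bond to nitrogen gives a step that the two limits leave unreadable from compound 1 to compound 3, unreadable because of the limit of > 100000 nM in this assay, at which 2 of the 3 values shown sit. The difference between the core of compound 1 and the core of compound 2 is not broken down here.

Compound 4 `O=C(/N=C(/NC(=O)c1cc2ccccc2s1)[Se]Cc1ccccc1)c1cc2ccccc2s1` carries the same change, (a group of 8 heavy atoms (7 carbon, 1 selenium; one six-membered aromatic ring of carbon only) in place of a group of 2 heavy atoms (1 carbon, 1 sulfur; no ring), on a carbon with a double bond to nitrogen). The measured step offers no size to carry over, so compound 4 is expected to sit near compound 2, with a step of a 1.1-fold higher number from compound 2 to compound 4 (0.04 log units; within the scatter) expected. For compound 4 the estimate is 80000 nM, between 30000 nM and 200000 nM, with a fair chance that only a limit is reported.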

Compound 4, concentration lethal to 50% of the cells: 86300 nM
The estimate for compound 4 lay 1.1-fold (0.03 log units) below the measured number, within the range that was stated.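

In this assay the selenium-bearing group in place of methylsulfanyl gives a 1.2-fold higher number from compound 2 to compound 4 (0.08 log units; within the scatter), so on the core of compound 2 this change leaves the number within the scatter. On the core of compound 1 the same change cannot be read, since compound 1 and compound 3 both give only limits: the limit of > 100000 nM in this assay, at which 2 of the 4 values shown sit. The series therefore holds one readable step on one core, which neither confirms nor refutes that the change carries from one core to the other.

Still open, going by these compounds, is whether a longer chain, an amine or a carboxylic acid in place of methylsulfanyl on this carbon would also stay within the scatter. Also open, on these data alone, is whether any such group would give a readable number on the core of compound 1.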